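The source may hold more compounds than are shown below. What is called first, only, known or untested is meant among the compounds shown, and "the series" means these compounds.

Working notes on the cytotoxicity series. Compound 1 `CSc1ccccc1NC(=O)Nc1cc(C)nc2ccccc12` was tested in an ADME assay on HEK293 cells (Homo sapiens) for cytotoxicity, with a stated time of 72 h; on this read-out higher numbers stand for an effect only at larger amounts of compound and lower numbers for an effect already at smaller amounts. In this assay compound 1 gives > 25000 nM, which is a limit of the assay rather than a number. Compound 2 `CSc1ccc(NC(=O)Nc2cc(C)nc3ccccc23)cc1` gives 24000 nM in this assay. Compound 3 `Cc1cc(NC(=O)Nc2ccc(F)c(F)c2)c2ccccc2n1` gives > 25000 nM in this assay, again a limit of the assay. Compound 1 therefore stands at the limit of > 25000 nM in this assay, at which 2 of the 3 values shown sit, a position it shares with compound 3, while compound 2 lies within the usual scatter of that point. Among the compounds with values here, no two measured compounds differ in one place, so no measured step is available to lean on.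

The next compound, compound 4 `COc1ccccc1NC(=O)Nc1cc(C)nc2ccccc12`, is not yet measured. It differs from compound 1 by methoxy in place of methylsulfanyl on an aromatic carbon. The change is expected to be none beyond the usual scatter, an expected step that the limit leaves unreadable from compound 1 to compound 4, because the value of compound 1 is the limit of > 25000 nM in this assay, at which 2 of the 3 values shown sit. Compound 4 is estimated at 30000 nM in this assay, with a range from 12000 nM to 80000 nM.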

Compound 4, half-maximal effective concentration: > 25000 nM
Compound 4 was reported as a limit (the forecaster's own chance of this, stated with the estimate: 70%); the middle value does not contradict the limit.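

In this assay, compound 1 and compound 4 are both reported only as limits, so no step can be read between them: the limit of > 25000 nM in this assay, at which 3 of the 4 values shown sit.

The compounds shown leave open whether methoxy in place of methylsulfanyl on an aromatic carbon changes the read-out at all.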